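Allyl on the pyrazole nitrogen: a repeated step

The compounds below may be only part of what the source reports. "The series", "measured", "known", "first", "only" and "open" are said of these compounds alone.

Three sulfonamides have been measured in a functional assay on A2780 cells (Homo sapiens) for cytotoxicity, read by MTT assay, with a stated time of 72 h; a higher number here means a weaker inhibitor, a lower number a stronger inhibitor. Compound 1 `CCOc1ccc(NS(=O)(=O)c2ccc(C)cc2)c2cn[nH]c12` gives 55100 nM, and compound 2 `C=CCn1ncc2c(NS(=O)(=O)c3ccc(C)cc3)ccc(OCC)c21`, which differs by allyl in place of hydrogen on an aromatic nitrogen, gives 61600 nM; the step of a 1.1-fold higher number from compound 1 to compound 2 (0.05 log units; within the scatter). Compound 3 `Cc1ccc(S(=O)(=O)Nc2ccc3c[nH]nc3c2)cc1` gives 86600 nM. The difference between the cores of compound 1 and compound 3 is not broken down here. Compound 4 `C=CCn1cc2ccc(NS(=O)(=O)c3ccc(C)cc3)cc2n1` has not yet been measured; it differs from compound 3 by allyl in place of hydrogen on an aromatic nitrogen, the same change, at the same kind of place, as from compound 1 to compound 2. Because that earlier step was a 1.1-fold higher number from compound 1 to compound 2 (0.05 log units; within the scatter), the step of a 1.1-fold higher number from compound 3 to compound 4 (0.04 log units; within the scatter) is expected to be similarly small. Compound 4 is therefore estimated at 95000 nM, between 45000 nM and 200000 nM in this assay.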

Compound 4, half-maximal inhibitory concentration: 4890 nM
The estimate for compound 4 lay 19-fold (1.29 log units) above the measured number; the measured number lies below the stated range.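

In this assay, allyl in place of hydrogen on an aromatic nitrogen gives an 18-fold lower number from compound 3 to compound 4 (1.25 log units; beyond the scatter), so the size of this step did not carry over from one core to the other: the same change on two cores in this assay, a 1.1-fold higher number (0.05 log units; within the scatter) from compound 1 to compound 2 and an 18-fold lower number (1.25 log units; beyond the scatter) from compound 3 to compound 4, 20-fold (1.30 log units) apart, beyond the scatter of two such steps

The two pairs show that, in this series, the effect of the change depends on the core that carries it. They do not show which difference between the core of compound 1 and the core of compound 3 is responsible, and they give no rule for any other core.

On these data alone, it remains open whether the large step from compound 3 is specific to allyl or would also appear with methyl, a longer chain or benzyl on that nitrogen. As far as these compounds go, it is also open how a chain ending in an amine or a carboxylic acid would behave there.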